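The source may report more compounds than this note shows. Statements on the series, on what has been measured and on what is new or still open speak of the compounds shown alone.

Measured compounds:
compound 1, `N#C/C(=C\c1ccc([N+](=O)[O-])cc1)C(=O)c1c[nH]c2ccccc12` — 35000 nM in a functional assay on MCF7 cells (Homo sapiens) for inhibition, read by MTT assay, with a stated time of 72 h; a lower number here means a stronger inhibitor of growth, a higher number a weaker inhibitor of growth
compound 2, `COc1ccc(CNC(=O)/C(C#N)=C/c2ccc[nH]2)cc1` — 34000 nM in this assay

Of the compounds shown here, two have been measured so far. In this assay compound 1 gives 35000 nM and compound 2 gives 34000 nM. Compound 2 has the lower of the two numbers, but its gap to compound 1 lies within the scatter of repeated measurements, so the two cannot be told apart on this evidence. Among the measured compounds shown here, no step between measured compounds is available, as the two share no common core that differs in one place only.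

The next compound, compound 3 (`COc1ccc(CNC(=O)/C(C#N)=C/c2ccc(Cl)cc2)cc1`), is not yet measured. It differs from compound 2 in one place: 4-chlorophenyl in place of 1H-pyrrol-2-yl on a double-bonded chain carbon bound to a double-bonded chain carbon. For the measured compounds named here, nothing among the measured compounds speaks to this particular exchange, so no direction is indicated. The expected step of a 1.1-fold lower number from compound 2 to compound 3 (0.05 log units; within the scatter) is therefore small, with either direction open and none beyond the scatter favoured. Compound 3 is estimated at 30000 nM in this assay, in a range from 8000 nM to 120000 nM.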

Compound 3, concentration for 50% growth inhibition: 11000 nM
Beside the measured number, compound 3's estimate is 2.7-fold (0.44 log units) above it; measured number inside the range.
By their numbers in this assay, from the lowest: compound 3; then compounds 2 and 1 (each within the scatter of the next).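

In this assay, the exchange of 1H-pyrrol-2-yl for 4-chlorophenyl on a double-bonded chain carbon bound to a double-bonded chain carbon gives a 3.1-fold lower number from compound 2 to compound 3 (0.49 log units; beyond the scatter). Among the compounds shown here, this is the only step read so far, and it shows that the number responds to a change at this position, which the earlier pair of compounds could not show. The step is modest and rests on a single pair in which the ring, the chlorine and the hydrogen-bond donor of the leaving group all change at once, and nothing available accounts for the shift.

The compounds shown leave open whether the chlorine or the six-membered ring carries the step, a question that a plain phenyl, a 4-fluorophenyl or a 4-bromophenyl at the same place would address. They also leave open whether the step would hold with another group on the amide nitrogen, such as a longer alkyl chain or a chain ending in a carboxylic acid, in place of the group that compound 2 and compound 3 share.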